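Swapping the methylsulfonyl for an aryl sulfonyl group

This account rests on a few compounds, and the source may have more. Where it says the series, first, only, none or still open, it means among the compounds named here.

The series shares the core of compound 1 `Nc1cncc(-c2cnc(N)nc2)c1`. In an assay on isolated protein for binding affinity to phosphatidylinositol 4,5-bisphosphate 3-kinase catalytic subunit beta isoform (Homo sapiens) (a higher number here means weaker binding, a lower number tighter binding), compound 1 gives only a limit, > 40000 nM. Compound 2 `CS(=O)(=O)Nc1cncc(-c2cnc(N)nc2)c1` gives 5200 nM, the higher of the two numbers measured. Going by the values given here, the step of an at least 7.6-fold lower number from compound 1 to compound 2 (0.88 log units; beyond the scatter) is the one measured step, and it rests on the limit of compound 1 (the limit of > 40000 nM in this assay, at which 1 of the 3 values shown sits). Compound 3 `Nc1ncc(-c2cncc(NS(=O)(=O)c3cccc(C(F)(F)F)c3)c2)cn1` gives 430 nM, a lower number than compound 2. Compound 4 `COc1ccc(S(=O)(=O)Nc2cncc(-c3cnc(N)nc3)c2)cc1` differs from compound 2 by 4-methoxyphenyl in place of methyl on a sulfonyl sulfur. Since compound 3 with an aryl sulfonyl gives 430 nM, compound 4 is expected to follow the same direction, estimated at 700 nM (range 200 nM to 2500 nM), a step of a 7.4-fold lower number from compound 2 to compound 4 (0.87 log units; beyond the scatter).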

Compound 4, dissociation constant: 500 nM
For compound 4 the middle estimate is 1.4-fold (0.15 log units) above the measured one; the range from low to high includes it.
By their numbers in this assay, from the lowest: compounds 3 and 4 (each within the scatter of the next); then compound 2. At a limit, above all of these: compound 1.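

At the sulfonyl sulfur, 4-methoxyphenyl in place of methyl gives a 10-fold lower number from compound 2 to compound 4 (1.02 log units; beyond the scatter) in this assay, a step at this position that rests on two measured numbers and not on a limit. Compound 3 and compound 4 lie within the scatter of each other, so this assay does not separate their two aryl groups. Nothing measured here gives a reason for the step.

From the compounds shown here alone, whether a plain phenyl, a cyclohexyl or a longer alkyl chain on the sulfur would keep this level of binding stays open. So does the effect of an amine or a carboxylic acid on the aryl ring.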